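Carbamoyl to isopropoxycarbonyl: working notes on compound 3

The source may report more compounds than this note shows. Statements on the series, on what has been measured and on what is new or still open speak of the compounds shown alone.

In a functional assay on the whole organism for inhibition, with Rattus norvegicus as the target, read by paw edema, with stated times of 1 h and 3 h (on this read-out lower numbers stand for an effect already at smaller amounts and higher numbers for an effect only at larger amounts of compound), compound 1 (`C/C(=N\OCC(N)=O)c1ccc(Cl)cc1`) gives 24 mg/kg and compound 2 (`C/C(=N\NCC(=O)O)c1ccc(Cl)cc1`) gives 22 mg/kg as its value. Going by the values given here, these two numbers lie within the scatter of each other, so compound 1 stands level with the only other measured compound.

Compound 3 (`C/C(=N\OCC(=O)OC(C)C)c1ccc(Cl)cc1`) has isopropoxy in place of amino on a carbonyl carbon and keeps the rest of compound 1 unchanged.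

Among the compounds with values here, one measured step bears on this, and only indirectly. It puts (carboxymethyl)amino in place of carbamoylmethoxy on a double-bonded nitrogen, and it amounts to a 1.1-fold lower number from compound 1 to compound 2 (0.04 log units; within the scatter) in size. Within the data shown here, that change also removes the amide of compound 1, but no measured pair swaps amino for isopropoxy on that carbonyl carbon. A single step within the scatter is thin support, so no shift beyond the scatter is expected in this assay and the range is kept wide.

The expected change is a 1.0-fold higher number from compound 1 to compound 3 (0.02 log units; within the scatter) in size. Compound 3 is estimated at 25 mg/kg (expected range 10 mg/kg to 60 mg/kg).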

Compound 3, dose for half-maximal effect: 50 mg/kg
Compound 3: middle estimate off by 2.0-fold (0.30 log units), on the low side, within the range that was stated.
By their numbers in this assay, from the lowest: compounds 2 and 1 (each within the scatter of the next); then compound 3.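

In this assay, going by these compounds alone, isopropoxy in place of amino on a carbonyl carbon comes to a 2.1-fold higher number from compound 1 to compound 3 (0.32 log units; beyond the scatter) and is the first step to lie beyond the scatter. The earlier step, a 1.1-fold lower number from compound 1 to compound 2 (0.04 log units; within the scatter), also removes the amide of compound 1 but changes the group on the double-bonded nitrogen as a whole, so it could not isolate this carbonyl carbon; the new pair shows that the read-out responds to a change at this position alone, with the amino compound giving the lower number. No measurement bears on the reason for this shift.

The compounds shown leave open whether the step follows the loss of amino, with its hydrogen-bond donor, or the entry of isopropoxy, since one pair changes both at once. Methoxy or a longer alkoxy chain on the same carbonyl carbon, a methylamino group, or a hydroxyl giving the carboxylic acid would each separate these readings, and a single modest step does not yet establish a trend.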